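The source may hold more compounds than are shown below. What is called first, only, known or untested is meant among the compounds shown, and "the series" means these compounds.

Measured so far in a functional assay on L1210 cells (Mus musculus) for inhibition; on this read-out higher numbers stand for weaker inhibition and lower numbers for stronger inhibition:
- compound 1 `C=C1[C@@H](O)[C@H](n2cnc3c(N)nc(N)nc32)O[C@@H]1CO`: > 200000 nM
- compound 2 `C=C1[C@H](n2cnc3c(Cl)nc(N)nc32)O[C@H](CO)[C@H]1O`: 10000 nM
- compound 3 `C=C1[C@H](n2cnc3c(N)nc(N)nc32)O[C@H](CO)[C@H]1O`: 8200 nM

The value for compound 1, > 200000 nM, is a limit of the assay and not a number. Compound 3 gives 8200 nM and compound 2 gives 10000 nM, two values within the scatter of each other.

The next step goes from compound 3 to compound 4 `C=C1[C@H](n2cnc3c(O)nc(N)nc32)O[C@H](CO)[C@H]1O`, with hydroxy in place of amino on an aromatic carbon. Among the compounds with values here, one measured step bears on this change, at the same carbon: a 1.2-fold lower number from compound 2 to compound 3 (0.09 log units; within the scatter), with amino in place of chloro. That step lies within the scatter, so no step beyond the scatter is expected in this assay, and no direction is favoured. The expected step is a 1.4-fold lower number from compound 3 to compound 4 (0.14 log units; within the scatter). Within the data shown here, with only one step as a guide, the range stays wide. For compound 4 the estimated value is 6000 nM, with an expected range from 1000 nM to 40000 nM.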

Compound 4, half-maximal inhibitory concentration: 8500 nM
The estimate for compound 4 lay 1.4-fold (0.15 log units) below the measured number; measured number inside the range.
By their numbers in this assay, from the lowest: compounds 3, 4 and 2 (each within the scatter of the next). At a limit, above all of these: compound 1.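

In this assay, hydroxy reads the same as the two groups already tried on this aromatic carbon, with a 1.0-fold higher number from compound 3 to compound 4 (0.02 log units; within the scatter) and a 1.2-fold lower number from compound 2 to compound 4 (0.07 log units; within the scatter). Within the data shown here, the earlier compounds gave only a single exchange here, amino for chloro, whereas chloro, amino and hydroxy now form a set of three that this read-out does not separate. No measured property in these data bears on why the three groups read alike.

Still open, going by these compounds, is whether a thiol, a methoxy group or a longer amine chain on this carbon would give a step beyond the scatter. Also open, on these data alone, is whether the same exchanges would read alike on the core of compound 1.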